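This account rests on a few compounds, and the source may have more. Where it says the series, first, only, none or still open, it means among the compounds named here.

Compound 1 `O=C(COc1ccc(C(=O)/C=C/c2ccccc2Cl)cc1)N[C@H]1CCOC1=O` gives 17400 nM in a functional assay on MCF7 cells (Homo sapiens) for antiproliferative activity, read by MTT assay, with a stated time of 72 h; on this read-out higher numbers stand for weaker inhibition and lower numbers for stronger inhibition. Compound 2 `CC(C)c1ccc(NCC(=O)N[C@H]2CCOC2=O)cc1` reaches only the limit of this assay, > 64000 nM. Compound 3 `Cc1cc(Cl)ccc1NCC(=O)N[C@H]1CCOC1=O` likewise reaches only the limit, > 64000 nM.

Compound 3 therefore stands at the limit of > 64000 nM in this assay, at which 2 of the 3 values shown sit, and no number for it is known beyond that. Compound 4 `O=C(CNc1ccc(Cl)cc1Cl)N[C@H]1CCOC1=O` differs from compound 3 by chloro in place of methyl on an aromatic carbon. Among the compounds with values here, no pair of measured compounds shows this change, so nothing tells how large its effect is. Since compound 3 sits at the limit of this assay, the step is expected to be a number no higher from compound 3 to compound 4 (the limit leaves the size open), none beyond the scatter, with compound 4 most likely again reported only as a limit. In this assay compound 4 is estimated at 64000 nM, in a range from 25000 nM to 200000 nM.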

Compound 4, half-maximal inhibitory concentration: > 64000 nM
Compound 4: no number, only a limit (the forecaster's own chance of this, stated with the estimate: 70%); the middle value lies on the limit itself.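

Compound 3 and compound 4 both stand only at a limit in this assay, so the step between them cannot be read: the limit of > 64000 nM in this assay, at which 3 of the 4 values shown sit.

The compounds shown leave open how large an effect chloro in place of methyl on an aromatic carbon has.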